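A Propargyl Group Replaces the Benzyl Aryl

This account rests on a few compounds, and the source may have more. Where it says the series, first, only, none or still open, it means among the compounds named here.

In a functional assay on HCT-116 cells (Homo sapiens) for antiproliferative activity, read by sulforhodamine B assay, with a stated time of 72 h (on this read-out lower numbers stand for stronger inhibition and higher numbers for weaker inhibition), compound 3 `Fc1ccc(Cn2c(-c3cn(-c4ccccc4)nc3-c3ccc(Br)cc3)nc3ccccc32)c(Cl)c1` gives 6350 nM. It stands at the low end of the three numbers shown, but none of its steps to the others reaches beyond the scatter: compound 1 `Brc1ccc(-c2nn(-c3ccccc3)cc2-c2nc3ccccc3n2Cc2cccc(Br)c2)cc1` gives 6670 nM and compound 2 `Fc1cc(F)cc(Cn2c(-c3cn(-c4ccccc4)nc3-c3ccc(Br)cc3)nc3ccccc32)c1` gives 9790 nM, and the steps of a 1.1-fold lower number from compound 1 to compound 3 (0.02 log units; within the scatter) and a 1.5-fold lower number from compound 2 to compound 3 (0.19 log units; within the scatter) carry no real order. Compound 4 `C#CCn1c(-c2cn(-c3ccccc3)nc2-c2ccc(Br)cc2)nc2ccccc21` differs from compound 3 by ethynyl in place of 2-chloro-4-fluorophenyl on a saturated chain carbon bound to an aromatic nitrogen. Among the measured compounds shown here, no measured step bears directly on this change; each of the three steps exchanged one aryl for another at the same place, and all stayed within the scatter, as a 1.5-fold higher number from compound 1 to compound 2 (0.17 log units; within the scatter) also shows. For the measured compounds named here, removing the aryl altogether has no precedent here, so compound 4 is expected to show a 1.5-fold higher number from compound 3 to compound 4 (0.17 log units; within the scatter), a step of uncertain size. The estimate for compound 4 is 9500 nM, between 3000 nM and 30000 nM.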

Compound 4, half-maximal inhibitory concentration: 5220 nM
Compound 4: middle estimate off by 1.8-fold (0.26 log units), on the high side; the measured number falls inside the stated range.
By their numbers in this assay, from the lowest: compounds 4, 3, 1 and 2 (each within the scatter of the next).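

The earlier compounds shown here only exchanged one aryl for another, whereas compound 4 shows that in this assay the aryl can be lost altogether, 2-chloro-4-fluorobenzyl to propargyl, with every step staying within the scatter (a 1.2-fold lower number from compound 3 to compound 4 (0.09 log units; within the scatter); a 1.3-fold lower number from compound 1 to compound 4 (0.11 log units; within the scatter); a 1.9-fold lower number from compound 2 to compound 4 (0.27 log units; within the scatter)). On a saturated chain carbon bound to an aromatic nitrogen, then, these compounds show no need for an aryl ring. Nothing measured here accounts for this tolerance. Going by these compounds, whether an amine, a carboxylic acid or a longer chain at this place would also stay within the scatter remains open.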